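Thiophen-2-yl in place of pyridin-2-yl in the series

A few compounds are considered here, and "the series" means these few. Any claim that something is new, unique, unknown or untested is made for them only; others in the source may bear on it.

In a functional assay on MDA-MB-435 cells (Homo sapiens) for cytotoxicity, read by MTT assay, with a stated time of 72 h (on this read-out lower numbers stand for stronger inhibition and higher numbers for weaker inhibition), compound 1 `COc1ccc(CNC(=O)c2nc(Br)c3cccnc3c2N[C@H]2CC[C@H](N)CC2)cc1` gives 5000 nM and compound 2 `N[C@H]1CC[C@H](Nc2c(C(=O)NCc3ccc(Cl)cc3Cl)nc(Br)c3cccnc23)CC1` gives 5800 nM while compound 3 `N[C@H]1CC[C@H](Nc2c(C(=O)NCc3ccccn3)nc(Br)c3cccnc23)CC1` gives 4000 nM so compound 3 stands within the scatter of both others. Compound 4 `N[C@H]1CC[C@H](Nc2c(C(=O)NCc3cccs3)nc(Br)c3cccnc23)CC1` differs from compound 3 in one place: thiophen-2-yl in place of pyridin-2-yl on a saturated chain carbon bound to an amide-type nitrogen with thiophen-2-yl in place of pyridin-2-yl on a saturated chain carbon bound to an amide-type nitrogen. The measured steps at this same place bear on the change. 2,4-dichlorophenyl in place of 4-methoxyphenyl gave a 1.2-fold higher number from compound 1 to compound 2 (0.06 log units; within the scatter) and pyridin-2-yl in place of 4-methoxyphenyl gave a 1.3-fold lower number from compound 1 to compound 3 (0.10 log units; within the scatter) and pyridin-2-yl in place of 2,4-dichlorophenyl gave a 1.5-fold lower number from compound 2 to compound 3 (0.16 log units; within the scatter) and all three stay within the scatter. Going by the values given here, no measured compound yet carries thiophen-2-yl. On those three steps, no step beyond the scatter is expected in this assay for this change. The estimated step is a 1.1-fold higher number from compound 3 to compound 4 (0.05 log units; within the scatter) and so stays within the scatter. Compound 4 is estimated at 4500 nM with an expected range from 2200 nM to 9000 nM in this assay.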

Compound 4, half-maximal inhibitory concentration: 4100 nM
Compound 4: middle estimate off by 1.1-fold (0.04 log units), on the high side, within the range that was stated.
By their numbers in this assay, from the lowest: compounds 3, 4, 1 and 2 (each within the scatter of the next).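

In this assay thiophen-2-yl, the only five-membered aromatic ring in the set, gives a 1.0-fold higher number from compound 3 to compound 4 (0.01 log units; within the scatter) and, measured against the two substituted phenyl groups, gives a 1.4-fold lower number from compound 2 to compound 4 (0.15 log units; within the scatter) and a 1.2-fold lower number from compound 1 to compound 4 (0.09 log units; within the scatter) with all three steps within the scatter. Exchanging the six-membered ring with nitrogen for the five-membered ring with sulfur on a saturated chain carbon bound to an amide-type nitrogen therefore leaves the number flat, and none of the four compounds goes against this. No measurement on hand offers an explanation for this flatness.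

All groups shown at this place are aromatic rings, so the effect of a saturated ring such as cyclohexyl or a chain ending in an amine stays open. Going by these compounds, whether any group at this place can produce a step beyond the scatter also stays open.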